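Amide-substituent notes on the coumarin-pyrazoline series

This account rests on a few compounds, and the source may have more. Where it says the series, first, only, none or still open, it means among the compounds named here.

Compound 1 `CCC(=O)N1N=C(c2cc3ccccc3oc2=O)CC1c1ccccc1` carries a propanoyl group on the shared core, and in a functional assay on PC-3 cells (Homo sapiens) for cytotoxicity, read by MTT assay, with a stated time of 48 h (a lower number here means a stronger inhibitor, a higher number a weaker inhibitor), compound 1 gives 4370 nM. Compound 2 `O=C(CNC1CC1)N1N=C(c2cc3ccccc3oc2=O)CC1c1ccccc1` differs in that the saturated chain carbon bound to the carbonyl carbon bears a cyclopropylamino group in place of methyl, and in this assay compound 2 gives 28500 nM. Going by the values given here, that change gave a 6.5-fold higher number from compound 1 to compound 2 (0.81 log units; beyond the scatter), so compound 2 stands as the higher of the two numbers measured so far, with compound 1 as its only neighbour.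

Compound 3 `CC(C)CNCC(=O)N1N=C(c2cc3ccccc3oc2=O)CC1c1ccccc1` keeps the amino-bearing chain of compound 2 and changes only the group on the amine nitrogen: isobutyl in place of cyclopropyl on an amine nitrogen. Among the compounds with values here, no measured step touches this position; the single step from compound 1 to compound 2 concerns the introduction of the amino group itself, not its substituent, and offers no direction for swapping one alkyl group for another there. The step from compound 2 to compound 3 is therefore expected to stay within the scatter, a 1.1-fold lower number from compound 2 to compound 3 (0.06 log units; within the scatter). On that basis compound 3 is estimated at 25000 nM, with a range from 9000 nM to 70000 nM.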

Compound 3, half-maximal inhibitory concentration: 1920 nM
Beside the measured number, compound 3's estimate is 13-fold (1.11 log units) above it; the measured number lies below the stated range.
By their numbers in this assay, from the lowest: compound 3; then compound 1; then compound 2.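

Working notes on the amine nitrogen: in this assay the group on this nitrogen proves decisive in its own right, since isobutyl in place of cyclopropyl gives a 15-fold lower number from compound 2 to compound 3 (1.17 log units; beyond the scatter) and the amino-bearing chain alone therefore does not fix the number. The earlier step, a 6.5-fold higher number from compound 1 to compound 2 (0.81 log units; beyond the scatter) for cyclopropylamino in place of methyl, suggested that an amino group on this chain carbon raises the number, but isobutylamino in place of methyl gives a 2.3-fold lower number from compound 1 to compound 3 (0.36 log units; beyond the scatter) and so reverses that direction, leaving compound 1 ranked between the two amines. Nothing on hand explains why these two groups on the same nitrogen part so widely.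

On these data alone, with only cyclopropyl and isobutyl on this nitrogen, it remains open whether a straight butyl chain, a cyclobutyl ring or a second methyl group on the nitrogen would fall with compound 3 or with compound 2. As far as these compounds go, it also remains open how the isobutylamino group behaves on a longer chain leading to the carbonyl carbon, so no trend can yet be drawn for this position.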